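From 4-methylphenyl to 1-methyl-1H-indol-3-yl on the shared core

The source may report more compounds than this note shows. Statements on the series, on what has been measured and on what is new or still open speak of the compounds shown alone.

Among the measured compounds shown here, in a functional assay on B16-F0 cells (Mus musculus) for inhibition, read by CCK-8 assay, with a stated time of 48 h (on this read-out higher numbers stand for weaker inhibition and lower numbers for stronger inhibition), compound 3 (`COc1cc(-c2ccnc3cc(-c4ccc(C)cc4)nn23)cc(OC)c1OC`) reads 21 nM and holds the lowest number so far. In this assay compound 2 (`COc1cc(-c2ccnc3cc(-c4ccc(Cl)cc4)nn23)cc(OC)c1OC`) reads 4090 nM and stands well above it. Compound 1 (`COc1cc(-c2cc3nccc(-c4c[nH]c5ccccc45)n3n2)cc(OC)c1OC`) gives > 10000 nM in this assay and this is a limit of the assay, not a number.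

Compound 4 (`COc1cc(-c2ccnc3cc(-c4cn(C)c5ccccc45)nn23)cc(OC)c1OC`) is still unmeasured. It carries 1-methyl-1H-indol-3-yl in place of 4-methylphenyl on an aromatic carbon of a five-membered aromatic ring with 2 nitrogen (1-methyl-1H-indol-3-yl in place of 4-methylphenyl on an aromatic carbon).

For the measured compounds named here, the one measured step at this place is a 190-fold lower number from compound 2 to compound 3 (2.29 log units; beyond the scatter) and it is large, with methyl in place of chloro on an aromatic carbon. Going by the values given here, a small substitution here can therefore move the number far, but no measured step replaces the whole group. The forecast stays wide, with a rise more likely than a fall.

The expected outcome is a 1.4-fold higher number from compound 3 to compound 4 (0.15 log units; within the scatter) as a central estimate, which would not clear the scatter. For compound 4 the estimated value is 30 nM with an expected range from 5 nM to 300 nM in this assay.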

Compound 4, half-maximal inhibitory concentration: 185 nM
Estimate against measurement, compound 4: 6.2-fold (0.79 log units) below; measured number inside the range.
By their numbers in this assay, from the lowest: compound 3; then compound 4; then compound 2. At a limit, above all of these: compound 1.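

Exchanging the whole group on this aromatic carbon for 1-methyl-1H-indol-3-yl gives an 8.8-fold higher number from compound 3 to compound 4 (0.94 log units; beyond the scatter) in this assay, so 4-methylphenyl remains the better of the two. The same exchange gives a 22-fold lower number from compound 2 to compound 4 (1.34 log units; beyond the scatter), so this position accepts a group of two fused aromatic rings, and the new group reads between the two substituted phenyl groups rather than beyond either. Nothing measured here accounts for this order.

Still open, on these data alone, is how a methoxy group or an amine in place of the methyl of 4-methylphenyl would read in this assay. Also open is what the methyl on the indole nitrogen of compound 4 contributes at this position, as the compounds shown offer no single-place comparison for it.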